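A Longer Hydroxy Chain on the Shared Core

This account rests on a few compounds, and the source may have more. Where it says the series, first, only, none or still open, it means among the compounds named here.

In a functional assay on DU-145 cells (Homo sapiens) for cytotoxicity, read by MTT assay (on this read-out higher numbers stand for weaker inhibition and lower numbers for stronger inhibition), compound 1 `CCCC(O)CC(=O)O[C@H](CC=C(C)C)C1=CC(=O)c2c(O)ccc(O)c2C1=O` gives only a limit, > 100000 nM. Compound 2 `CC(=O)OCCC(=O)O[C@H](CC=C(C)C)C1=CC(=O)c2c(O)ccc(O)c2C1=O` reads 15700 nM, while compound 3 `CCCCC(O)CC(=O)O[C@H](CC=C(C)C)C1=CC(=O)c2c(O)ccc(O)c2C1=O` reads 45300 nM, the higher of the two actual numbers. The gap between them is a 2.9-fold higher number from compound 2 to compound 3 (0.46 log units; beyond the scatter). Compound 4 `CCCCCCC(C)(O)CC(=O)O[C@H](CC=C(C)C)C1=CC(=O)c2c(O)ccc(O)c2C1=O` differs from compound 3 by 1-hydroxy-1-methylheptyl in place of 1-hydroxypentyl on a saturated chain carbon bound to a carbonyl carbon, with 1-hydroxy-1-methylheptyl in place of 1-hydroxypentyl on a saturated chain carbon bound to a carbonyl carbon. Among the compounds with values here, the nearest precedent is a single chain extension, an at least 2.2-fold lower number from compound 1 to compound 3 (0.34 log units; beyond the scatter), and its size rests on a limit. A modest step toward a lower number is therefore expected in this assay, a 2.3-fold lower number from compound 3 to compound 4 (0.36 log units; beyond the scatter). Compound 4 is estimated at 20000 nM, with an expected range of 6000 nM to 70000 nM.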

Compound 4, half-maximal inhibitory concentration: > 100000 nM
Compound 4 was reported as a limit; the forecaster's own chance of this, stated with the estimate: 7%; middle value at least 5.0-fold (0.69 log units) from the limit.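

In this assay, the trend does not simply continue along the chain at this place: the earlier at least 2.2-fold lower number from compound 1 to compound 3 (0.34 log units; beyond the scatter) is followed by an at least 2.2-fold higher number from compound 3 to compound 4 (0.34 log units; beyond the scatter) on moving to 1-hydroxy-1-methylheptyl. The acetoxymethyl group keeps its lead over this longest chain, with an at least 6.3-fold higher number from compound 2 to compound 4 (0.80 log units; beyond the scatter). The readings for compound 1 and compound 4 are both limits, and the step between them cannot be read: the limit of > 100000 nM in this assay, at which 2 of the 4 values shown sit.

The added methyl and the longer chain enter together, and the compounds shown do not separate them. From the compounds shown here alone, a 1-hydroxyheptyl group without the methyl, or an amine at this place, remains open.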